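From a Hydroxyphenyl Amide to a Bromophenyl Amide

The compounds below may be only part of what the source reports. "The series", "measured", "known", "first", "only" and "open" are said of these compounds alone.

Measured compounds:
compound 1 `COc1ccc(-c2cnc(NC(=O)c3ccc(O)cc3)n2C)cc1`: in a toxicity assay on THP-1 cells (Homo sapiens) for inhibition (a higher number here means that more compound is tolerated, a lower number that less compound is tolerated), compound 1 gives > 100000 nM, a limit of the assay and not a number.
compound 2 `COc1ccc(-c2cnc(NC(=O)c3ccc(F)cc3)n2-c2ccccc2)cc1`: in this assay compound 2 gives 8800 nM.
compound 3 `Cc1ccc(C(=O)Nc2ncc(-c3ccccc3)n2C)cc1`: in this assay compound 3 gives > 50000 nM, again a limit of the assay.

Compound 1 stands at the top of what has been seen, at the limit of > 100000 nM in this assay, at which 1 of the 3 values shown sits, so it is known only that it is tolerated up to that limit. Compound 3 sits at the limit of > 50000 nM in this assay, at which 1 of the 3 values shown sits. Only compound 2 has a numeric value.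

The compound still to be measured is compound 4 `COc1ccc(-c2cnc(NC(=O)c3ccccc3Br)n2C)cc1`. It differs from compound 1 in one place: 2-bromophenyl in place of 4-hydroxyphenyl on a carbonyl carbon.

Among the compounds with values here, no single-change step between measured compounds exists to calibrate this change, and compound 2 differs from compound 4 in more than one place, so its value shows only that a numeric value is reachable. For compound 4 a modest shift toward less tolerated is expected, with a fair chance of another limit, so the expected step is an at least 2.0-fold lower number from compound 1 to compound 4 (0.30 log units; that floor lies within the scatter). Compound 4 is thus estimated at 50000 nM, with a range from 15000 nM to 150000 nM.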

Compound 4, half-maximal cytotoxic concentration: > 100000 nM
Compound 4 gave a limit, no number; the forecaster's own chance of this, stated with the estimate: 40%; middle value at least 2.0-fold (0.30 log units) from the limit.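

Compound 4, like compound 1, gives only a limit of the assay and not a number: the limit of > 100000 nM in this assay, at which 2 of the 4 values shown sit. No step can be read between compound 1 and compound 4. The compounds shown leave open whether 2-bromophenyl in place of 4-hydroxyphenyl changes what is tolerated at all.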